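The compounds below may be only part of what the source reports. "The series", "measured", "known", "first", "only" and "open" are said of these compounds alone.

Measured compounds:
Compound 1 `O=C(c1cccc(Cl)c1)N1CCn2nc(-c3ccccn3)cc2C1`, which in a functional assay on HEK293 cells for negative allosteric modulation of metabotropic glutamate receptor 5 (Homo sapiens), read by calcium flux, with a stated time of 20 min (a higher number here means a weaker inhibitor, a lower number a stronger inhibitor), gives 176 nM.
Compound 2 `O=C(c1ccccc1)N1CCn2nc(-c3ccc(F)cn3)cc2C1`, which in this assay gives 164 nM.

Compound 2 holds the lower of the two numbers, but its gap to compound 1 lies within the scatter of repeated measurements, so the two cannot be told apart on what is known here. Compound 3 `O=C(c1cccc(Cl)c1)N1CCn2nc(-c3ccc(F)cn3)cc2C1` has not yet been measured in this assay. It differs from compound 2 in one place: chloro in place of hydrogen on an aromatic carbon, on an aromatic carbon of the six-membered aromatic ring of carbon only, meta to a large group; read one bond further out, phenyl becomes 3-chlorophenyl. Among the compounds with values here, no pair among the measured compounds isolates this change, so there is no measured step to lean on. Compound 1 carries the same chloro group on the other pyridyl and sits close to compound 2. A modest step toward a lower number is expected for compound 3, though anything beyond the scatter would be unsupported by what has been measured. The step from compound 2 to compound 3 is estimated at a 1.7-fold lower number from compound 2 to compound 3 (0.24 log units; within the scatter). Compound 3 is accordingly expected to give about 95 nM in this assay, most likely between 30 nM and 300 nM.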

Compound 3, half-maximal inhibitory concentration: 150 nM
Estimate against measurement, compound 3: 1.6-fold (0.20 log units) below; low and high end bracket the measured number.
By their numbers in this assay, from the lowest: compounds 3, 2 and 1 (each within the scatter of the next).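

Within the data shown here, with compound 3, the chloro group can be read on its own for the first time: in this assay the change from phenyl to 3-chlorophenyl gives a 1.1-fold lower number from compound 2 to compound 3 (0.04 log units; within the scatter) and so cannot be told apart from hydrogen at this place, meta to a large group. Among these compounds, the fluoro group, read on its own for the first time as well, gives a 1.2-fold lower number from compound 1 to compound 3 (0.07 log units; within the scatter) and likewise stays within the scatter, so neither single change shifts the number measurably on this core. Nothing available bears on why these changes are so small.

From the compounds shown here alone, whether a larger group at this place, such as a methoxy group, an amine or a carboxylic acid, would move the number beyond the scatter remains open. Also open, going by these compounds, is whether chloro would read the same in a compound lacking the fluoro group.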